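The source may hold more compounds than are shown below. What is called first, only, known or untested is meant among the compounds shown, and "the series" means these compounds.

Compound 1 `CC(C)(C)NC(=O)c1cc2ccccc2oc1=O`: 7900 nM
Compound 2 `O=C(SCc1ccco1)c1cc2ccccc2oc1=O`: 210 nM
Compound 3 `O=C(Sc1ncccn1)c1cc2ccccc2oc1=O`: 7680 nM

These three compounds share one core and differ only in the group attached to the carbonyl. In an assay on isolated protein for inhibition of Amine oxidase [flavin-containing] B (Homo sapiens), read by fluorescence (on this read-out higher numbers stand for weaker inhibition and lower numbers for stronger inhibition), compound 2 gives 210 nM, compound 3 gives 7680 nM and compound 1 gives 7900 nM. Compound 3 thus stands second highest of the three numbers: its value and that of compound 1 lie within the scatter of each other, while compound 2 sits far lower. The only step measured among these compounds, a 37-fold higher number from compound 2 to compound 3 (1.56 log units; beyond the scatter), shows how strongly the group on the sulfur moves the number.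

Compound 4 `CCCCSC(=O)c1cc2ccccc2oc1=O` keeps the thioester of compounds 2 and 3 but carries butyl in place of pyrimidin-2-yl on a sulfur. For the measured compounds named here, the one step that bears on this change is the one that replaced (furan-2-yl)methyl by pyrimidin-2-yl on the same sulfur. Butyl, like (furan-2-yl)methyl, brings no ring to the sulfur, whereas pyrimidin-2-yl is an aromatic ring, so a large move back toward lower numbers is expected, roughly reversing the step of a 37-fold higher number from compound 2 to compound 3 (1.56 log units; beyond the scatter); in this assay compound 4 is expected to show a 13-fold lower number from compound 3 to compound 4 (1.11 log units; beyond the scatter). Compound 4 is therefore estimated at 600 nM, with a range from 150 nM to 2500 nM.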

Compound 4, half-maximal inhibitory concentration: 16000 nM
The estimate for compound 4 lay 27-fold (1.43 log units) below the measured number; the whole stated range lies below it.
By their numbers in this assay, from the lowest: compound 2; then compounds 3 and 1 (each within the scatter of the next); then compound 4.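

In this assay, propyl in place of furan-2-yl on a saturated chain carbon bound to a sulfur gives a 76-fold higher number from compound 2 to compound 4 (1.88 log units; beyond the scatter) and so shows that a ring-free chain on this sulfur does not reproduce the low number of compound 2. Butyl in place of pyrimidin-2-yl on the same sulfur gives a 2.1-fold higher number from compound 3 to compound 4 (0.32 log units; beyond the scatter) in the same direction, so among the three thioesters the presence or absence of a ring directly on the sulfur does not bring the number near that of compound 2. Butylsulfanyl in place of (tert-butyl)amino on a carbonyl carbon gives a 2.0-fold higher number from compound 1 to compound 4 (0.31 log units; beyond the scatter) and shows that the thioester link alone does not lower the number either, leaving compound 2 as the one low value so far.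

No measurement available here explains these differences. The compounds shown leave open whether the low number of compound 2 depends on furan-2-yl itself or would survive with a benzyl or (thiophen-2-yl)methyl group on the sulfur, and whether a (furan-2-yl)methylamino group on the carbonyl carbon would keep it without the sulfur.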